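Second chloro on the aryl ring, tried on a new core

A few compounds are considered here, and "the series" means these few. Any claim that something is new, unique, unknown or untested is made for them only; others in the source may bear on it.

Compound 1 `O=C1N(c2cccc(Cl)c2)CCN1C1CN2CCC1CC2` and compound 2 `O=C1N(c2cc(Cl)cc(Cl)c2)CCN1C1CN2CCC1CC2` share one core; compound 3 `Cc1[nH]cnc1CN1CCN(c2cccc(Cl)c2)C1=O` and compound 4 `Cc1[nH]cnc1CN1CCN(c2cc(Cl)cc(Cl)c2)C1=O` share another, and the difference between the two cores is not broken down here. In a functional assay (Cavia porcellus) for antagonist activity at Serotonin 3 (5-HT3) receptor (Homo sapiens) (a lower number here means a stronger inhibitor, a higher number a weaker inhibitor), compound 1 gives 30.9 nM, compound 2 gives 45 nM and compound 3 gives 12 nM. Compound 3 stands with the lowest number of the three, beyond the scatter from both others. The change from compound 1 to compound 2 is chloro in place of hydrogen on an aromatic carbon and brought a 1.5-fold higher number from compound 1 to compound 2 (0.16 log units; within the scatter). Compound 4 carries the same change, (chloro in place of hydrogen on an aromatic carbon), on the core of compound 3. The step expected from compound 3 to compound 4 in this assay is a 1.5-fold higher number from compound 3 to compound 4 (0.18 log units; within the scatter), because a 1.5-fold higher number from compound 1 to compound 2 (0.16 log units; within the scatter) stayed within the scatter. Compound 4 is estimated at 18 nM, from 8 nM to 40 nM.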

Compound 4, antagonist equilibrium constant: 5.62 nM
Estimate against measurement, compound 4: 3.2-fold (0.51 log units) above; measured number below the stated range.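

On the core of compound 3, in this assay, the added chloro gives a 2.1-fold lower number from compound 3 to compound 4 (0.33 log units; beyond the scatter), a modest step toward the stronger end. The same change therefore does not carry over unchanged between these two cores, and the step on one core is a poor guide to the step on the other: the same change on two cores in this assay, a 1.5-fold higher number (0.16 log units; within the scatter) from compound 1 to compound 2 and a 2.1-fold lower number (0.33 log units; beyond the scatter) from compound 3 to compound 4, 3.1-fold (0.49 log units) apart, beyond the scatter of two such steps This rests on a single pair per core, so it does not show which part of the cores sets the difference, nor does it give a rule for any further core.

Open, from the compounds shown here alone, is how a fluoro, a methoxy or a nitrile in place of the second chloro would behave on each core. Also open, going by these compounds, is whether such groups would show the same split between the two cores.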